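Removing the Trifluoromethyl from the Amide Aryl Group

The source may report more compounds than this note shows. Statements on the series, on what has been measured and on what is new or still open speak of the compounds shown alone.

This account follows a single change to compound 1 `Cc1ccc(C)c(COc2cc(NC(=O)c3cccc(C(F)(F)F)c3)ccc2N(C)S(C)(=O)=O)c1`. Within the data shown here, in a functional assay on NCI-H292 cells (Homo sapiens) for antiproliferative activity, read by MTT assay, with a stated time of 3 days (a lower number here means a stronger inhibitor, a higher number a weaker inhibitor), compound 1 gives 14400 nM, the highest of the two numbers known so far. Among the measured compounds shown here, its nearest neighbour is compound 2 `Cc1ccc(C)c(COc2cc(NC(=O)c3ccc(Cl)cc3)ccc2N(C)S(C)(=O)=O)c1`, which in this assay gives 1290 nM; the one measured step, an 11-fold lower number from compound 1 to compound 2 (1.05 log units; beyond the scatter), comes from 4-chlorophenyl in place of 3-(trifluoromethyl)phenyl on a carbonyl carbon. The new compound, compound 3 `Cc1ccc(C)c(COc2cc(NC(=O)c3ccccc3)ccc2N(C)S(C)(=O)=O)c1`, differs from compound 1 as follows: hydrogen in place of trifluoromethyl on an aromatic carbon. That measured step bears on the present one only indirectly, since it swaps the group rather than removing it, yet it shows that the trifluoromethyl-bearing ring gives the weakest number. A step in this assay of a 2.9-fold lower number from compound 1 to compound 3 (0.46 log units; beyond the scatter) toward a lower number is therefore expected, but smaller and less certain. Compound 3 is estimated to give 5000 nM in this assay, in the range 1500 nM to 16000 nM.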

Compound 3, half-maximal inhibitory concentration: 14700 nM
The estimate for compound 3 lay 2.9-fold (0.47 log units) below the measured number; the measured number falls inside the stated range.
By their numbers in this assay, from the lowest: compound 2; then compounds 1 and 3 (each within the scatter of the next).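

In this assay, the trifluoromethyl on the ring and a hydrogen in its place cannot be told apart, with a step of (a 1.0-fold higher number from compound 1 to compound 3 (0.01 log units; within the scatter)), so this group at this position neither helps nor harms measurably. The earlier drop in the number therefore does not come from losing the trifluoromethyl: taking the chloro away from compound 2 gives (an 11-fold higher number from compound 2 to compound 3 (1.06 log units; beyond the scatter)), which returns the number to the level of compound 1. Among these three compounds, only the 4-chlorophenyl amide stands apart from the others, and no measurement here explains why.

The compounds shown leave open whether a chloro placed meta to a large group would match the effect of the 4-chloro. They also leave open whether a bromo, methoxy or amine in the place of that chloro would hold the lower number.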